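Swapping the benzyl substituent in a rhodanine-type amide series

The compounds below may be only part of what the source reports. "The series", "measured", "known", "first", "only" and "open" are said of these compounds alone.

Measured compounds:
Compound 1, `O=C(CN1C(=O)/C(=C/c2ccc(-c3ccc(Cl)cc3)o2)SC1=S)NCc1ccc(C(F)(F)F)cc1`, in a functional assay on REH cells (Homo sapiens) for cytotoxicity, read by MTT assay, with a stated time of 72 h (a higher number here means a weaker inhibitor, a lower number a stronger inhibitor), gives 170000 nM.
Compound 2, `N#Cc1cc(NC(=O)CN2C(=O)/C(=C/c3ccc(-c4ccc(Cl)cc4)o3)SC2=S)ccc1C(F)(F)F`, in this assay reaches only the assay limit, > 250000 nM.
Compound 3, `O=C(CN1C(=O)/C(=C/c2ccc(-c3ccc(Cl)cc3)o2)SC1=S)NCc1ccccc1Cl`, in this assay gives 70000 nM.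

Compound 3 holds the lowest of the two real numbers here; compound 1 is its nearest neighbour, and the gap is told by a 2.4-fold lower number from compound 1 to compound 3 (0.39 log units; beyond the scatter). Compound 2 sits at a limit (the limit of > 250000 nM in this assay, at which 1 of the 3 values shown sits), so from it only an at least 3.5-fold lower number from compound 2 to compound 3 (0.55 log units; beyond the scatter) and an at least 1.4-fold higher number from compound 1 to compound 2 (0.16 log units; that floor lies within the scatter) can be read, each as a floor. All three share the same core and differ only in the group carried on the amide-type nitrogen.

Compound 4, `Cc1cccc(CNC(=O)CN2C(=O)/C(=C/c3ccc(-c4ccc(Cl)cc4)o3)SC2=S)c1`, is the next step from compound 3: 3-methylphenyl in place of 2-chlorophenyl on a saturated chain carbon bound to an amide-type nitrogen. Among the measured compounds shown here, the one measured step that bears directly on this position is the change of a substituted benzyl group, a 2.4-fold lower number from compound 1 to compound 3 (0.39 log units; beyond the scatter), which was modest. A second exchange of one substituted benzyl for another is therefore expected to move the number by about that much, and most plausibly back toward compound 1, since compound 3 is already the lowest value seen. The expected step is a 1.6-fold higher number from compound 3 to compound 4 (0.20 log units; within the scatter). Compound 4 is thus estimated at 110000 nM, with a range from 45000 nM to 250000 nM.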

Compound 4, half-maximal inhibitory concentration: 53000 nM
For compound 4 the middle estimate is 2.1-fold (0.32 log units) above the measured one; the range from low to high includes it.
By their numbers in this assay, from the lowest: compounds 4 and 3 (each within the scatter of the next); then compound 1. At a limit, above all of these: compound 2.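

In this assay, replacing 2-chlorobenzyl with 3-methylbenzyl gives a 1.3-fold lower number from compound 3 to compound 4 (0.12 log units; within the scatter), so this exchange on the amide-type nitrogen leaves no readable difference, even though both the ring substituent and its place on the ring change. Compound 4 also shows that the gap to compound 1 does not belong to compound 3 alone, since a second substituted benzyl group gives a 3.2-fold lower number from compound 1 to compound 4 (0.51 log units; beyond the scatter), and so compounds 3 and 4 stand together, apart from compound 1. The value of compound 2 is a limit, which means that an at least 4.7-fold lower number from compound 2 to compound 4 (0.67 log units; beyond the scatter) can be read only as a floor: the limit of > 250000 nM in this assay, at which 1 of the 4 values shown sits.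

Because the swap changes the substituent and its place together, these compounds cannot show which of the two matters, or whether either does, and 3-chlorobenzyl or 2-methylbenzyl would be needed to separate them. From the compounds shown here alone, it also remains open how the number would respond to an amine or a carboxylic acid on the benzyl ring, or to a longer chain between the amide-type nitrogen and that ring.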